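The source may report more compounds than this note shows. Statements on the series, on what has been measured and on what is new or still open speak of the compounds shown alone.

Three related compounds have been measured in a functional assay (Homo sapiens) for antiproliferative activity; a lower number here means a stronger inhibitor of growth, a higher number a weaker inhibitor of growth. Compound 1 `Cc1cn2c(/C=N/NC(=N)N)c(-c3ccncc3)nc2s1` gives 39800 nM, compound 2 `N=C(N)N/N=C/c1c(-c2ccccn2)nc2sc(Cl)cn12` gives 15100 nM, and compound 3 `N=C(N)N/N=C/c1c(-c2cccnc2)nc2sc(Cl)cn12` gives 36300 nM. Compound 3 therefore lies within the scatter of compound 1, while its number is clearly higher than that of compound 2.

Compound 4 `N=C(N)N/N=C/c1c(-c2ccncc2)nc2sc(Cl)cn12` differs from compound 3 in one place, with pyridin-4-yl in place of pyridin-3-yl on an aromatic carbon. Among the compounds with values here, the only measured step that exchanges one pyridinyl group for another is a 2.4-fold higher number from compound 2 to compound 3 (0.38 log units; beyond the scatter), a modest change. Elsewhere compound 4 is not the same as compound 1, which already carries pyridin-4-yl and offers the closest guide with its value of 39800 nM. On this evidence, no step beyond the scatter is expected in this assay, and no direction can be favoured with confidence. The expected change is a 1.1-fold lower number from compound 3 to compound 4 (0.04 log units; within the scatter). Compound 4 is estimated at 33000 nM, with an expected range of 16000 nM to 65000 nM.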

Compound 4, concentration for total growth inhibition: 13800 nM
The estimate for compound 4 lay 2.4-fold (0.38 log units) above the measured number; measured number outside the range, below it.
By their numbers in this assay, from the lowest: compounds 4 and 2 (each within the scatter of the next); then compounds 3 and 1 (each within the scatter of the next).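

In this assay, this position on the five-membered aromatic ring proves sensitive to the pyridinyl attachment point, as pyridin-4-yl in place of pyridin-3-yl gives a 2.6-fold lower number from compound 3 to compound 4 (0.42 log units; beyond the scatter). Pyridin-3-yl now stands apart from both other isomers, while pyridin-4-yl in place of pyridin-2-yl gives only a 1.1-fold lower number from compound 2 to compound 4 (0.04 log units; within the scatter), so the two steps among these three compounds do not follow a simple progression in the attachment point. With pyridin-4-yl held constant, chloro in place of methyl on the core gives a 2.9-fold lower number from compound 1 to compound 4 (0.46 log units; beyond the scatter), the first single-place comparison showing that this second site also affects the number.

The data offered here give no explanation for either difference. From the compounds shown here alone, it remains open whether pyridin-2-yl and pyridin-3-yl would show the same pattern with methyl on the core, and how a plain phenyl ring at this position or bromo in place of chloro would compare.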